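The source may report more compounds than this note shows. Statements on the series, on what has been measured and on what is new or still open speak of the compounds shown alone.

Measured compounds:
- Compound 1 `CCn1c(SCC(=O)Nc2ccc(/C(C)=N/O)cc2)nnc1-c1cc(OC)c(OC)c(OC)c1`: 61%
- Compound 2 `C=CCn1c(SCC(=O)Nc2ccc(C(C)=O)cc2)nnc1-c1ccc(OC)c(OC)c1`: 64%
- Compound 3 `C=CCn1c(SCC(=O)Nc2ccc(/C(C)=N/O)cc2)nnc1-c1cc(OC)c(OC)c(OC)c1`: 64%

In a functional assay on the whole organism (strain albino) for inhibition, with Rattus norvegicus as the target, read by paw edema, with stated times of 30 min and 5 h, at a dose of 0.28 mmol/kg by the oral route (on this read-out lower numbers stand for less inhibition and higher numbers for more inhibition at the one dose given (going by the name of the read-out)), compound 3 gives 64%, level with compound 2 at the digits shown; together these two stand highest of the three numbers, and the gap to compound 1 is within the scatter. Going by the values given here, the one measured single step, a number 3 percentage points higher from compound 1 to compound 3 (within the scatter), lies within the scatter as well.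

Compound 4 `C=CCn1c(SCC(=O)Nc2ccc(C(C)=O)cc2)nnc1-c1cc(OC)c(OC)c(OC)c1` is the next compound to be measured. It differs from compound 3 in one place: a group of 3 heavy atoms (2 carbon, 1 oxygen; no ring) in place of a group of 4 heavy atoms (2 carbon, 1 nitrogen, 1 oxygen; no ring), on an aromatic carbon. Among the compounds with values here, no measured step changes this group by itself, so nothing bears on the change directly. Compound 2 carries the acetyl group already and in this assay compound 2 gives 64%, the same number as compound 3, but compound 2 also differs from compound 3 in the substitution of the other aromatic ring, so its value is only an indirect hint. On that footing the step from compound 3 to compound 4 is expected to be none beyond the scatter, namely a number 1 percentage points lower from compound 3 to compound 4 (within the scatter). For compound 4 the estimate in this assay is therefore 63%, with a range from 52% to 73%.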

Compound 4, a percentage reported as inhibition, in the whole organism at one dose (the size of the read-out at that dose, not a potency): 64%
Estimate against measurement, compound 4: 1 percentage points below, and the stated range covers the measured number.
By their numbers in this assay, from the lowest: compounds 1, 2, 3 and 4 (each within the scatter of the next).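

Going by these compounds alone, the acetyl group and the group it replaces, on an aromatic carbon para to a large group, can be compared directly for the first time, and the exchange gives no change at the digits printed from compound 3 to compound 4 (within the scatter) in this assay, so the hydrogen-bond donor of the leaving group, absent from acetyl, is not needed to hold the read-out at this one dose. With acetyl held constant, methoxy in place of hydrogen on the other aromatic ring gives no change at the digits printed from compound 2 to compound 4 (within the scatter), which turns the earlier indirect hint from compound 2 into a measured step and shows that neither exchange moves this assay beyond the scatter. Nothing at hand gives a reason for either result.

From the compounds shown here alone, what an amine or a carboxylic acid on this aromatic carbon would give remains open, as does whether acetyl matches the larger group when the ring nitrogen carries the ethyl chain of compound 1. All of these readings come from a single oral dose, so they leave open whether the compounds would also stay level at other doses.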